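The source may hold more compounds than are shown below. What is called first, only, known or untested is meant among the compounds shown, and "the series" means these compounds.

Compound 1 `CCCCc1ccc2[nH]c(-c3ccc(OC)cc3)c(C=O)c2c1` gives 22 nM 
Compound 2 `Cc1ccc(-c2[nH]c3ccc(C)cc3c2C=O)cc1` gives 165 nM 

Both were tested in a functional assay on MCF7 cells (Homo sapiens) for antiproliferative activity, with a stated time of 5 days (a higher number here means a weaker inhibitor, a lower number a stronger inhibitor), and compound 2 (165 nM) holds the higher, weaker number of the two, set against compound 1 (22 nM). That gap lies beyond the scatter. Compound 3 `CCCCc1ccc2[nH]c(-c3ccc(C)cc3)c(C=O)c2c1` differs from compound 2 in one place (propyl in place of hydrogen on a saturated chain carbon bound to an aromatic carbon), with propyl in place of hydrogen on a saturated chain carbon bound to an aromatic carbon, so methyl becomes butyl. Compound 1 (22 nM) also carries butyl, although it differs elsewhere as well. A sizeable fall towards stronger inhibition is therefore expected, with an estimated step (a 5.5-fold lower number from compound 2 to compound 3 (0.74 log units; beyond the scatter)) well beyond the scatter. Compound 3 is estimated at 30 nM (range 12 nM to 80 nM).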

Compound 3, half-maximal inhibitory concentration: 54 nM
Compound 3: middle estimate off by 1.8-fold (0.26 log units), on the low side; low and high end bracket the measured number.
By their numbers in this assay, from the lowest: compound 1; then compound 3; then compound 2.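

In this assay, methyl becoming butyl on the saturated chain carbon bound to an aromatic carbon gives a 3.1-fold lower number from compound 2 to compound 3 (0.49 log units; beyond the scatter) and so shows that this position accepts the longer chain, with a real gain. Methyl in place of methoxy on an aromatic carbon gives a 2.5-fold higher number from compound 1 to compound 3 (0.39 log units; beyond the scatter) as a separate, one-place change, so the chain is not the only group that moves the number. Nothing here explains either step. From the compounds shown here alone, whether a hexyl chain or a terminal amine would do better at the chain position remains open. So does how a hydroxyl or a chlorine would compare with methoxy.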